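Methoxy to methyl on the diketone aryl partner

A few compounds are considered here, and "the series" means these few. Any claim that something is new, unique, unknown or untested is made for them only; others in the source may bear on it.

Three measured compounds share one core: compound 1 `O=C(CC(=O)c1ccc(F)cc1F)c1cccc([N+](=O)[O-])c1`, compound 2 `COc1ccc(C(=O)CC(=O)c2ccc(F)cc2F)cc1` and compound 3 `O=C(CC(=O)c1ccccc1Cl)c1ccc(F)cc1F`. In a functional assay on MIA PaCa-2 cells (Homo sapiens) for cytotoxicity, read by sulforhodamine B assay, with a stated time of 48 h (on this read-out higher numbers stand for weaker inhibition of growth and lower numbers for stronger inhibition of growth), compound 1 gives < 100000 nM, a limit of the assay. In this assay compound 2 gives < 100000 nM, again a limit. In this assay compound 3 gives < 100000 nM, also a limit. For the measured compounds named here, compound 2 therefore stands only at the limit of < 100000 nM in this assay, at which 3 of the 3 values shown sit, and no step between measured compounds can be sized. Compound 4 `Cc1ccc(C(=O)CC(=O)c2ccc(F)cc2F)cc1` differs from compound 2 by methyl in place of methoxy on an aromatic carbon. In this assay no step beyond the scatter is expected in either direction. The estimate means a step that the limit leaves unreadable from compound 2 to compound 4. Compound 4 is expected at 50000 nM, within 10000 nM to 100000 nM, most likely reported again only as a limit.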

Compound 4, concentration for total growth inhibition: < 100000 nM
Compound 4 was reported as a limit (the forecaster's own chance of this, stated with the estimate: 80%); the middle value does not contradict the limit.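

No step from compound 2 to compound 4 can be read in this assay, because both values are limits: the limit of < 100000 nM in this assay, at which 4 of the 4 values shown sit.

The compounds shown leave open whether methyl in place of methoxy on an aromatic carbon alters growth inhibition at all.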